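This account rests on a few compounds, and the source may have more. Where it says the series, first, only, none or still open, it means among the compounds named here.

Measured so far:
compound 1, `Cc1cccc(C2CNCC2C(=O)Nc2cc3cc[nH]c(=O)c3cc2Cl)c1`: 5 nM
compound 2, `NCC(=O)Nc1cc2cc[nH]c(=O)c2cc1Cl`: 120 nM

In an assay on isolated protein for inhibition of Rho-associated protein kinase 2 (Homo sapiens), read by a luciferase reporter (on this read-out lower numbers stand for stronger inhibition and higher numbers for weaker inhibition), compound 1 gives 5 nM, the lowest of the two numbers. Compound 2, which lacks the substituted pyrrolidine and carries only the aminoacetyl amide on the shared core, gives 120 nM in this assay, a higher number that lies beyond the usual scatter of repeated measurements. For the measured compounds named here, no pair of measured compounds differs in a single place, so no single-point step is available from the measured set.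

Compound 3, `O=C(Nc1cc2cc[nH]c(=O)c2cc1Cl)C1CNCC1c1cccc(Br)c1`, differs from compound 1 by bromo in place of methyl on an aromatic carbon. Neither measured compound carries a halogen at this position, so the expectation rests on compound 1 alone. The step of no change at the digits printed from compound 1 to compound 3 (within the scatter) in this assay is expected to be small, with no direction beyond the scatter. Compound 3 is therefore estimated at 5 nM in this assay, within a range of 2 nM to 15 nM.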

Compound 3, half-maximal inhibitory concentration: 2 nM
Compound 3: the middle estimate sits 2.5-fold (0.40 log units) above what was measured, within the range that was stated.
By their numbers in this assay, from the lowest: compound 3; then compound 1; then compound 2.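

The position meta to a large group on the aromatic ring tolerates a change of substituent: in this assay, bromo in place of methyl gives a 2.5-fold lower number from compound 1 to compound 3 (0.40 log units; beyond the scatter) as a modest step. For the compounds shown here, this is the first comparison between compounds that differ in one place, and it shows that the 3-methylphenyl group is not needed for a low number, as the 3-bromophenyl group reads lower still. Nothing available explains the lower number with bromo.

Only these two groups are shown at this position, so it stays open how chloro, methoxy or an amine on the same carbon would read. On these data alone, it is also open how an unsubstituted phenyl would compare with either of them, and so whether methyl and bromo each add to the inhibition.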